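A few compounds are considered here, and "the series" means these few. Any claim that something is new, unique, unknown or untested is made for them only; others in the source may bear on it.

Among the measured compounds shown here, three related compounds have been tested in an ADME assay on L02 cells (Homo sapiens) for antiproliferative activity, read by CCK-8 assay, with a stated time of 6 days (a lower number here means a stronger inhibitor, a higher number a weaker inhibitor), so far, and only one gave a number. Compound 1 (`N#Cc1ccc(N2CCc3cc(-c4cccnc4)ccc32)cc1C(F)(F)F`) stands at "not determined" (no result reported) there, and compound 3 (`Cc1noc(C)c1-c1cccc2c1CCCN2c1ccc(C#N)c(C(F)(F)F)c1`) also stands at "not determined" (no result reported) with no result to compare. Compound 2 (`CCN(c1ccc(C#N)c(Cl)c1)c1cc(-c2ccnn2C)ccc1C`) gives 6230 nM in this assay, and as the only figure available it cannot yet be ranked against anything.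

The next compound to be measured is compound 4 (`CCN(c1ccc(C#N)c(Cl)c1)c1cc(-c2cccnc2)ccc1C`). It differs from compound 2 in a single place (pyridin-3-yl in place of 1-methyl-1H-pyrazol-5-yl on an aromatic carbon), with pyridin-3-yl in place of 1-methyl-1H-pyrazol-5-yl on an aromatic carbon. For the measured compounds named here, no measured pair shows what a swap of this kind does, so the data point in neither direction. The expectation is therefore no change beyond the usual scatter of repeated measurements, with compound 2 at 6230 nM as the only anchor. The expected size of the change is a 1.0-fold lower number from compound 2 to compound 4 (0.02 log units; within the scatter) in this assay, a small step with no firm direction. For compound 4 the estimated value is 6000 nM in this assay, with an expected range from 2500 nM to 14000 nM as a wide allowance for resting on one number.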

Compound 4, half-maximal inhibitory concentration: 12700 nM
Estimate against measurement, compound 4: 2.1-fold (0.33 log units) below, within the range that was stated.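

In this assay the aromatic carbon para to a methyl group proves sensitive to which ring it carries: pyridin-3-yl in place of 1-methyl-1H-pyrazol-5-yl gives a 2.0-fold higher number from compound 2 to compound 4 (0.31 log units; beyond the scatter) and so a modestly weaker inhibitor. The two groups have the same number of heavy atoms and neither has a hydrogen-bond donor, yet exchanging a five-membered aromatic ring with two hetero atoms for a six-membered aromatic ring with one is enough to move the number beyond the usual scatter. No measurement shown here explains why the number moves.

One pair cannot separate the contribution of the ring size, the number of ring nitrogens and the methyl group on the pyrazole, nor show whether the same step would hold on another core. A plain phenyl ring, an amine such as morpholine or a carboxylic acid on this same carbon would show how far the number can move and whether a ring nitrogen is needed there at all.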